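Nitro for Fluoro on the Shared Core of Compound 1

The source may hold more compounds than are shown below. What is called first, only, known or untested is meant among the compounds shown, and "the series" means these compounds.

Compound 1, with the structure `Cn1cnnc1SCCc1nnc(SCC(=O)Nc2nc3ccc(F)cc3s2)o1`, is the starting point of this account. In an ADME assay on NIH3T3 cells (Mus musculus) for cytotoxicity, read by MTT assay, with a stated time of 24 h (a lower number here means a stronger inhibitor, a higher number a weaker inhibitor), compound 1 gives > 500 ug/mL, a limit of the assay rather than a number. Compound 2, with the structure `Cn1cnnc1SCCc1nnc(SCC(=O)Nc2ccc(F)cc2)o1`, carries a fluorophenyl amide in place of the fused bicyclic amide. In this assay compound 2 likewise gives > 500 ug/mL, again a limit and not a number. So compound 1 stands at the edge of what this assay can report, and the only other value known sits at the same edge, as shown by the limit of > 500 ug/mL in this assay, at which 2 of the 2 values shown sit.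

Compound 3, with the structure `Cn1cnnc1SCCc1nnc(SCC(=O)Nc2nc3ccc([N+](=O)[O-])cc3s2)o1`, differs from compound 1 by nitro in place of fluoro on an aromatic carbon. Among the compounds with values here, no measured pair differing in one place is available to size such a change. Given that both known values sit at the limit of > 500 ug/mL in this assay, at which 2 of the 2 values shown sit, no step beyond the scatter is expected in this assay, and the step of a number no higher from compound 1 to compound 3 (the limit leaves the size open) is expected to be essentially flat. Compound 3 is therefore estimated at 500 ug/mL, within 150 ug/mL to 1500 ug/mL, most likely reported again only as a limit in this assay.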

Compound 3, half-maximal inhibitory concentration: > 500 ug/mL
Compound 3 gave a limit, no number; the forecaster's own chance of this, stated with the estimate: 80%; the middle value sits exactly at the limit.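

Compound 3, like compound 1, is reported in this assay only as a limit, so no step can be read for nitro in place of fluoro between these two compounds: the limit of > 500 ug/mL in this assay, at which 3 of the 3 values shown sit.

The compounds shown leave open whether this change, or the change of amide seen in compound 2, alters the read-out at all, since none of them gives a number.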